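This account rests on a few compounds, and the source may have more. Where it says the series, first, only, none or still open, it means among the compounds named here.

Working notes on a set of compounds sharing the core of compound 1 `COc1cccc(/C=C/C(=O)c2ccc(OC)c3c2OC(C)(C)C=C3)c1`, varied only in the group on a double-bonded chain carbon bound to a double-bonded chain carbon. In a functional assay on SK-OV-3 cells (Homo sapiens) for antiproliferative activity, read by MTT assay, with a stated time of 24 h (on this read-out higher numbers stand for weaker inhibition and lower numbers for stronger inhibition), compound 1 gives 9360 nM. Compound 2 `COc1ccc(C(=O)/C=C/c2ccc3ccccc3n2)c2c1C=CC(C)(C)O2` gives 2350 nM in this assay. Compound 3 `COc1ccc(C(=O)/C=C/c2ccc(C(F)(F)F)cc2)c2c1C=CC(C)(C)O2` reaches only > 10000 nM in this assay, which is a limit of the assay and not a number; it sits at the limit of > 10000 nM in this assay, at which 1 of the 3 values shown sits. Of the two numbers shown, compound 1 stands at the highest, with compound 2 the nearest to it, and the gap between these two lies beyond the usual scatter.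

Compound 4 `COc1ccc(C(=O)/C=C/c2ccco2)c2c1C=CC(C)(C)O2` is not yet measured in this assay. It differs from compound 1 in one place: furan-2-yl in place of 3-methoxyphenyl on a double-bonded chain carbon bound to a double-bonded chain carbon. Within the data shown here, no step between measured compounds that differ in one place is available, so the expectation for this change rests on the structures alone. The step from compound 1 to compound 4 is expected to be small in this assay, about a 1.2-fold lower number from compound 1 to compound 4 (0.07 log units; within the scatter), with no direction that clearly exceeds the scatter. Compound 4 is accordingly estimated at 8000 nM, with a range from 2500 nM to 25000 nM.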

Compound 4, half-maximal inhibitory concentration: > 10000 nM
Compound 4: no number, only a limit; the forecaster's own chance of this, stated with the estimate: 35%; at least 1.2-fold (0.09 log units) between middle value and limit.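

In this assay compound 4 gives > 10000 nM, which is a limit of the assay and not a number. Furan-2-yl in place of 3-methoxyphenyl on a double-bonded chain carbon bound to a double-bonded chain carbon gives an at least 1.0-fold higher number from compound 1 to compound 4 (0.02 log units; that floor lies within the scatter), so this smaller five-membered aromatic ring brings no gain at this place, and only a floor can be read for the step. Compound 4 is the second compound in the series to stop at the limit rather than give a number: the limit of > 10000 nM in this assay, at which 2 of the 4 values shown sit.

From the compounds shown here alone, how far compound 4 lies beyond its limit stays open, so the true size of the step is unknown. Also open, going by these compounds, is what an amine or a carboxylic acid at this place would give in this assay.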